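A few compounds are considered here, and "the series" means these few. Any claim that something is new, unique, unknown or untested is made for them only; others in the source may bear on it.

Measured compounds: compound 1 `CCNC(=O)CCc1cccc2c1B(O)OC2` in a functional assay on MDA-MB-231 cells (Homo sapiens) for antiproliferative activity, read by MTT assay, with a stated time of 72 h (on this read-out lower numbers stand for stronger inhibition and higher numbers for weaker inhibition), gives a limit, > 100000 nM. Compound 2 `Cc1ccc(NC(=O)CCc2cccc3c2B(O)OC3)cc1` gives 1100 nM. Compound 3 `O=C(CCc1cccc2c1B(O)OC2)Nc1cccc(Br)c1` gives 720 nM.

Compound 3 holds the lowest of the two numbers, with compound 2 nearest; the step of a 1.5-fold lower number from compound 2 to compound 3 (0.18 log units; within the scatter) lies within the scatter. Compound 4 `COc1cc(OC)cc(-c2cccc(NC(=O)CCc3cccc4c3B(O)OC4)c2)c1` differs from compound 3 by 3,5-dimethoxyphenyl in place of bromo on an aromatic carbon. Going by the values given here, the large steps of an at least 90-fold lower number from compound 1 to compound 2 (1.95 log units; beyond the scatter) and an at least 130-fold lower number from compound 1 to compound 3 (2.14 log units; beyond the scatter) concern aryl in place of ethyl on the amide nitrogen, not a change on the aryl itself; the only step on the aryl, a 1.5-fold lower number from compound 2 to compound 3 (0.18 log units; within the scatter), is within scatter. Among the compounds with values here, no measured step covers a 3,5-dimethoxyphenyl entering here, so a step within the scatter is expected, a 1.1-fold lower number from compound 3 to compound 4 (0.04 log units; within the scatter). Compound 4 is estimated at 650 nM, between 150 nM and 3000 nM.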

Compound 4, half-maximal inhibitory concentration: 40 nM
Estimate against measurement, compound 4: 16-fold (1.21 log units) above, outside the stated range (below it).
By their numbers in this assay, from the lowest: compound 4; then compounds 3 and 2 (each within the scatter of the next). At a limit, above all of these: compound 1.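

In this assay, the aryl on the amide nitrogen proves sensitive to what it carries: 3,5-dimethoxyphenyl in place of bromo brings an 18-fold lower number from compound 3 to compound 4 (1.26 log units; beyond the scatter), whereas the earlier change on that aryl, a 1.5-fold lower number from compound 2 to compound 3 (0.18 log units; within the scatter), stayed within the scatter. This place, meta to a large group, therefore accepts a whole added aromatic ring with a clear shift in the number. Nothing shown gives a reason for this step. As far as these compounds go, whether plain phenyl, a pyridine or an amine at this place would do the same remains open. So does whether the methoxy groups matter at all.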